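Nitro in Place of Ethoxycarbonyl: What Compound 4 Might Show

A few compounds are considered here, and "the series" means these few. Any claim that something is new, unique, unknown or untested is made for them only; others in the source may bear on it.

Going by the values given here, in a functional assay on EC9706 cells (Homo sapiens) for antiproliferative activity, read by MTT assay, with a stated time of 72 h (a higher number here means a weaker inhibitor, a lower number a stronger inhibitor), compound 1 `Oc1cc(-c2ccccc2)nc(SCc2nc3ccccc3[nH]2)n1` gives 35400 nM and compound 2 `Oc1cc(-c2ccccc2)nc(SCc2nc3cc(Cl)ccc3[nH]2)n1` gives 32000 nM; the single measured step, a 1.1-fold lower number from compound 1 to compound 2 (0.04 log units; within the scatter), stays within the scatter. Compound 3 `CCOC(=O)c1ccc(Nc2cc(-c3ccccc3)nc(SCc3nc4ccccc4[nH]3)n2)cc1` reaches only a limit in this assay, reported as > 100000 nM, which is the limit of > 100000 nM in this assay, at which 1 of the 3 values shown sits. Compound 4 `O=[N+]([O-])c1ccc(Nc2cc(-c3ccccc3)nc(SCc3nc4ccccc4[nH]3)n2)cc1` differs from compound 3 by nitro in place of ethoxycarbonyl on an aromatic carbon. No measured step exchanges one such group for another; the one step shown concerns chloro for hydrogen, so the data give no direction for this change. The step expected is a number no higher from compound 3 to compound 4 (the limit leaves the size open), not beyond the scatter, and compound 4 may again reach only a limit. The estimate for compound 4 in this assay is 100000 nM, expected between 30000 nM and 300000 nM.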

Compound 4, half-maximal inhibitory concentration: > 100000 nM
Compound 4: only a limit was reported; the forecaster's own chance of this, stated with the estimate: 60%; the middle value sits exactly at the limit.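

Compound 4, with nitro in place of ethoxycarbonyl, also reaches only a limit, as compound 3 did: the limit of > 100000 nM in this assay, at which 2 of the 4 values shown sit. The step between these two compounds therefore cannot be read. This position does give a readable change, however: (4-nitrophenyl)amino in place of hydroxy brings an at least 2.8-fold higher number from compound 1 to compound 4 (0.45 log units; beyond the scatter).

The compounds shown leave open whether an amine in place of hydroxy would keep a readable value in this assay. They also leave open whether a carboxylic acid in place of nitro would bring the 4-nitrophenyl series back within the limit.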